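The compounds below may be only part of what the source reports. "The series", "measured", "known", "first", "only" and "open" are said of these compounds alone.

Measured so far in a functional assay on HeLa cells (Homo sapiens) for inhibition, read by CCK-8 assay, with a stated time of 48 h; on this read-out lower numbers stand for stronger inhibition and higher numbers for weaker inhibition:
- compound 1, `CC(C)c1ccc(Oc2ccc(O)c(O)c2)c(-c2ccsc2S(=O)(=O)NCCNC(=S)Nc2cc(C(F)(F)F)cc(C(F)(F)F)c2)c1`, gives > 20000 nM, which is a limit of the assay and not a number.
- compound 2, `O=S(=O)(NCCNC(=S)Nc1cc(C(F)(F)F)cc(C(F)(F)F)c1)c1sccc1-c1ccccc1Oc1ccc(O)c(O)c1`, gives > 50000 nM, again a limit.
- compound 3, `O=C(NCCNS(=O)(=O)c1ccc(-c2ccccc2OCc2ccccc2)s1)Nc1cccc([N+](=O)[O-])c1`, gives > 20000 nM, also a limit.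

Compound 1 therefore stands nowhere in particular on the numbers shown: only a limit is known for it, and the two other values are limits as well, two of the three sitting at the limit of > 20000 nM in this assay, at which 2 of the 3 values shown sit, and one at the limit of > 50000 nM in this assay, at which 1 of the 3 values shown sits. Among the measured compounds shown here, the single measured step between compounds that differ in one place, a step that the two limits leave unreadable from compound 1 to compound 2, is left unreadable by the two limits, so its size cannot be told.

Compound 4, `COc1ccc(Oc2ccc(C(C)C)cc2-c2ccsc2S(=O)(=O)NCCNC(=S)Nc2cc(C(F)(F)F)cc(C(F)(F)F)c2)cc1OC`, differs from compound 1 by 3,4-dimethoxyphenyl in place of 3,4-dihydroxyphenyl on an oxygen on an aromatic ring. For the measured compounds named here, no measured step bears on this change, and the one step that exists in this assay gives no readable size. With every value shown a limit, the step that the limit leaves unreadable from compound 1 to compound 4 is expected to be none beyond the scatter, and compound 4 is expected to stay at the limit. Compound 4 is estimated at 30000 nM, with a range from 8000 nM to 200000 nM, most likely reported as a limit only.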

Compound 4, half-maximal inhibitory concentration: 8300 nM
Compound 4: middle estimate off by 3.6-fold (0.56 log units), on the high side; measured number inside the range.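

In this assay, among the compounds shown here, 3,4-dimethoxyphenyl in place of 3,4-dihydroxyphenyl on an oxygen on an aromatic ring gives an at least 2.4-fold lower number from compound 1 to compound 4 (0.38 log units; beyond the scatter), so this position can move the read-out, which the earlier compounds could not show. For the compounds shown here, compound 1 is known only as a limit, so the step has a lower bound on its size and no exact size: the limit of > 20000 nM in this assay, at which 2 of the 4 values shown sit. The only other step between compounds that differ in one place cannot be read, so the dimethoxy change has nothing readable to be compared with.

The compounds shown do not separate the loss of the two hydrogen-bond donors from the gain in heavy atoms. As far as these compounds go, it remains open how a single methoxy group, or ethoxy groups in place of the two methoxy groups, would read here, and whether the isopropyl group matters once the 3,4-dimethoxyphenyl group is present.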